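The source may report more compounds than this note shows. Statements on the series, on what has been measured and on what is new or still open speak of the compounds shown alone.

The measured compounds:
Compound 1 `CC(C)c1sc(-c2ccccc2)c(C2CCCC2)c1/C=C/[C@@H](O)C[C@@H](O)CC(=O)O`: in an assay on microsomes for inhibition of 3-hydroxy-3-methylglutaryl-coenzyme A reductase (Rattus norvegicus) (on this read-out lower numbers stand for stronger inhibition and higher numbers for weaker inhibition), compound 1 gives 417 nM.
Compound 2 `CC(C)c1sc(-c2ccccc2)c(C2CCCCC2)c1/C=C/[C@@H](O)C[C@@H](O)CC(=O)O`: in this assay compound 2 gives 202 nM.
Compound 3 `CCCCCCCCc1sc(C(C)C)c(/C=C/[C@@H](O)C[C@@H](O)CC(=O)O)c1-c1ccc(F)cc1`: in this assay compound 3 reaches only the limit > 10000 nM, which is a limit of the assay and not a number.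

Compound 3 is thus the one of the three for which no number is known; its value sits at the limit of > 10000 nM in this assay, at which 1 of the 3 values shown sits. Compound 4 `CC(C)c1sc(-c2ccc(Cl)cc2)c(-c2ccc(F)cc2)c1/C=C/[C@@H](O)C[C@@H](O)CC(=O)O` differs from compound 3 in one place: 4-chlorophenyl in place of octyl on an aromatic carbon. Within the data shown here, the only measured step, a 2.1-fold lower number from compound 1 to compound 2 (0.31 log units; beyond the scatter), exchanges one ring for another of a different size and does not concern the group that changes here, so it gives no direct guide to the size of this step. What the values do show is that compound 1, with a phenyl group and a cyclopentyl ring on the shared core, gives 417 nM, and compound 2, with a phenyl group and a cyclohexyl ring, gives 202 nM. Compound 3, with the octyl chain, gives only a limit. Compound 4 carries two aromatic rings and no long chain, so a step back into the range of numbers is expected: an at least 33-fold lower number from compound 3 to compound 4 (1.52 log units; beyond the scatter). Compound 4 is therefore estimated at 300 nM, with a likely range from 50 nM to 3000 nM.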

Compound 4, half-maximal inhibitory concentration: 21 nM
Beside the measured number, compound 4's estimate is 14-fold (1.15 log units) above it, and the stated range ends above it.
By their numbers in this assay, from the lowest: compound 4; then compound 2; then compound 1. At a limit, above all of these: compound 3.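

Among these compounds, the place on the five-membered aromatic ring next to the ring sulfur proves highly sensitive in this assay: exchanging octyl for 4-chlorophenyl there gives an at least 470-fold lower number from compound 3 to compound 4 (2.67 log units; beyond the scatter), far more than the only earlier step, a 2.1-fold lower number from compound 1 to compound 2 (0.31 log units; beyond the scatter), a change of ring size elsewhere on the core. The value of compound 3 is a limit of the assay and not a number: the limit of > 10000 nM in this assay, at which 1 of the 4 values shown sits. Neither group carries a hydrogen-bond donor, a hydrogen-bond acceptor or a net charge, so this comparison sets an open chain against an aromatic ring, and with the ring in place compound 4 gives 21 nM.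

These compounds cannot tell whether the aromatic ring alone is enough or the chlorine on it also counts, nor how a shorter chain such as butyl, or a methoxy group in place of the chlorine, would fare at this place. On these data alone, compound 2 and compound 4 differ in more than one place, so the effect of a cyclohexyl ring against a 4-fluorophenyl group on the neighbouring ring atom also stays open.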